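This account rests on a few compounds, and the source may have more. Where it says the series, first, only, none or still open, it means among the compounds named here.

Compound 1 `COCOc1cc(/C=C/C(=O)OCC(=O)Nc2ccc(Cl)cc2)ccc1OCc1ccccc1` was tested in a functional assay on ECa-109 cells (Homo sapiens) for cytotoxicity, read by MTT assay, with a stated time of 72 h; a higher number here means a weaker inhibitor, a lower number a stronger inhibitor. In this assay compound 1 gives only a limit, > 200000 nM, and so stands at the limit of > 200000 nM in this assay, at which 1 of the 2 values shown sits. Compound 2 `O=C(COC(=O)/C=C/c1ccc(O)c(O)c1)Nc1ccc(Cl)cc1` gives 175000 nM in this assay. Compound 3 `COCOc1cc(/C=C/C(=O)OCC(=O)Nc2nccs2)ccc1OCc1ccccc1` differs from compound 1 in one place: 1,3-thiazol-2-yl in place of 4-chlorophenyl on an amide-type nitrogen. No measured pair covers this change, and the step cannot be read from the data shown. Little movement beyond the usual scatter is expected, and the expected step is a number no higher from compound 1 to compound 3 (the limit leaves the size open). Compound 3 is therefore estimated at about 200000 nM, within a range from 80000 nM to 500000 nM.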

Compound 3, half-maximal inhibitory concentration: > 200000 nM
Compound 3 was reported as a limit; the forecaster's own chance of this, stated with the estimate: 60%; the middle value lies on the limit itself.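

No step can be read from compound 1 to compound 3, as each gives only a limit: the limit of > 200000 nM in this assay, at which 2 of the 3 values shown sit.

The compounds shown leave open how far 1,3-thiazol-2-yl in place of 4-chlorophenyl on an amide-type nitrogen shifts the result in this assay.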